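The source may hold more compounds than are shown below. What is called first, only, known or untested is meant among the compounds shown, and "the series" means these compounds.

The series shares one small core, a dichloroacetamide attached to a benzene ring, and the compounds differ only in what sits on that ring. Compound 1 `O=C(Nc1ccccc1)C(Cl)Cl` carries no substituent, compound 2 `O=C(Nc1cccc(C(F)(F)F)c1)C(Cl)Cl` carries a trifluoromethyl group, and compound 3 `O=C(Nc1ccc(F)cc1)C(Cl)Cl` carries a fluoro group. In a functional assay on Bel-7402 cells (Homo sapiens) for antiproliferative activity, read by MTT assay, with a stated time of 72 h (a lower number here means a stronger inhibitor, a higher number a weaker inhibitor), compound 2 gives 5970 nM. Among the compounds with values here, for compound 1 the outcome in this assay stands as "not determined" (no result reported), and for compound 3 it stands as "not determined" (no result reported), so compound 3 has no number of its own to stand on; the only number in the set belongs to compound 2.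

Compound 4 `O=C(Nc1ccc(Br)cc1)C(Cl)Cl` has not been measured. It differs from compound 3 in one place: bromo in place of fluoro on an aromatic carbon. Within the data shown here, no measured pair in this set shows what such a swap does, so no size or direction for the step can be drawn from the data. Drawing on the single number available, that of compound 2 in this assay, compound 4 is expected to give about 8000 nM, within a range from 2000 nM to 40000 nM.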

Compound 4, half-maximal inhibitory concentration: 9770 nM
Estimate against measurement, compound 4: 1.2-fold (0.09 log units) below, within the range that was stated.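

Compound 3 has no single number in this assay, so no new step can be read from it to compound 4 at 9770 nM in that assay. From the compounds shown here alone, what replacing fluoro with bromo does to activity stays open. No supporting evidence is available to explain the value of compound 4.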